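Phenyl to furan-2-yl on a nucleoside core

A few compounds are considered here, and "the series" means these few. Any claim that something is new, unique, unknown or untested is made for them only; others in the source may bear on it.

Measured compounds:
compound 1, `COc1nc(N)nc2c1c(-c1ccccc1)cn2[C@@H]1O[C@H](CO)[C@@H](O)[C@H]1O` — > 20000 nM
compound 2, `COc1ncnc2c1c(-c1ccccc1)cn2[C@@H]1O[C@H](CO)[C@@H](O)[C@H]1O` — > 20000 nM

In a functional assay on HCT-116 cells (Homo sapiens), read by MTT assay, with a stated time of 72 h (on this read-out lower numbers stand for stronger inhibition and higher numbers for weaker inhibition), compound 1 reaches only a limit of the assay, > 20000 nM. Compound 2 likewise reaches only a limit in this assay, > 20000 nM. Within the data shown here, the one measured step, a step that the two limits leave unreadable from compound 1 to compound 2, is therefore unreadable in size; both values sit at the limit of > 20000 nM in this assay, at which 2 of the 2 values shown sit. Compound 2 thus stands at a limit, with no number to place it.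

Compound 3, `COc1ncnc2c1c(-c1ccco1)cn2[C@@H]1O[C@H](CO)[C@@H](O)[C@H]1O`, differs from compound 2 by furan-2-yl in place of phenyl on an aromatic carbon. Among the measured compounds shown here, no measured step touches this part of the shared core, so the expected size of the step of a number no higher from compound 2 to compound 3 (the limit leaves the size open) in this assay rests on the two limits alone, and no direction beyond the scatter is expected. For compound 3 in this assay the estimate is 20000 nM, within 5000 nM to 60000 nM, most likely again a limit.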

Compound 3, half-maximal inhibitory concentration: 40 nM
The estimate for compound 3 lay 500-fold (2.70 log units) above the measured number, outside the stated range (below it).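

In this assay, this aromatic carbon of the five-membered ring turns out to be a place where one change decides between a limit and a real number: furan-2-yl in place of phenyl gives an at least 500-fold lower number from compound 2 to compound 3 (2.69 log units; beyond the scatter). The earlier compounds shown here could not show this, since both carry phenyl, the step between them cannot be read, and neither gives a number: the limit of > 20000 nM in this assay, at which 2 of the 3 values shown sit. Among these compounds, compound 3 is thus the only compound here with a number, and it gives the shared core a measured point from which further steps can be read.

Whether the oxygen of furan-2-yl or the smaller five-membered ring accounts for the step stays open, and thiophen-2-yl or pyrrol-2-yl at this carbon would separate the two. Also open, as far as these compounds go, is what the amino group of compound 1 would do alongside furan-2-yl.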